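Aminopiperidine amides on the shared core: positional isomer

The compounds below may be only part of what the source reports. "The series", "measured", "known", "first", "only" and "open" are said of these compounds alone.

Measured in an assay on Sf21 cells for inhibition of MAP kinase-interacting serine/threonine-protein kinase 1 (Homo sapiens), read by luminescence and ADP-Glo, with stated times of 10 min and 40 min; a lower number here means a stronger inhibitor, a higher number a weaker inhibitor:
compound 1, `N[C@@H]1CCCN(C(=O)c2ccc(-c3ccc4ncc(-c5ccc6cnccc6c5)n4c3)cc2)C1`: 7.7 nM
compound 2, `NC1CCN(C(=O)c2ccc(-c3ccc4ncc(-c5ccc6cnccc6c5)n4n3)cc2)CC1`: 14.5 nM
compound 3, `O=C(c1ccc(-c2ccc3ncc(-c4ccc5ncccc5c4)n3c2)cc1)N1CCOCC1`: 371 nM

Compound 1 gives the lowest of the three numbers in this assay. Compound 2, which carries a 4-aminopiperidin-1-yl amide on a core differing from that of compound 1, gives a number within the scatter of compound 1, so no order between the two can be read. Compound 3, with a morpholine amide and another core, gives the highest number of the set, beyond the scatter from compound 1.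

Compound 4, `NC1CCN(C(=O)c2ccc(-c3ccc4ncc(-c5ccc6cnccc6c5)n4c3)cc2)CC1`, keeps the core and the amide of compound 1 and shifts only the amine position on the piperidine ring: 4-aminopiperidin-1-yl in place of 3-aminopiperidin-1-yl on a carbonyl carbon. Among the compounds with values here, no step between measured compounds isolates this change. Within the data shown here, the only guide is the 4-aminopiperidin-1-yl amide of compound 2, which gives 14.5 nM, a number within the scatter of compound 1. The step is therefore expected to be small, a 1.4-fold higher number from compound 1 to compound 4 (0.15 log units; within the scatter), with no direction beyond the scatter. Compound 4 is estimated at 11 nM, in the range 4 nM to 30 nM.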

Compound 4, half-maximal inhibitory concentration: 16.8 nM
Beside the measured number, compound 4's estimate is 1.5-fold (0.18 log units) below it; the measured number falls inside the stated range.
By their numbers in this assay, from the lowest: compounds 1, 2 and 4 (each within the scatter of the next, the first and the last beyond it); then compound 3.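

In this assay, within the data shown here, shifting the amine on the piperidine ring gives a 2.2-fold higher number from compound 1 to compound 4 (0.34 log units; beyond the scatter), so the amine position on this amide registers in the read-out, something the earlier compounds could not show since none of them differ in one place. The change also removes the defined stereocentre of the 3-aminopiperidin-1-yl group, so this one step carries both the amine shift and the loss of that stereocentre, and the two cannot be separated here. No evidence bearing on the origin of the step is available.

Open, going by these compounds, is how the opposite enantiomer of the 3-aminopiperidin-1-yl amide compares with compound 1 on the shared core. Also open, on these data alone, is whether a smaller cyclic amine, such as a 3-aminopyrrolidin-1-yl amide, or an open-chain aminoethyl amide would fit this position.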